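A few compounds are considered here, and "the series" means these few. Any claim that something is new, unique, unknown or untested is made for them only; others in the source may bear on it.

Values so far in a functional assay on NCI-H460 cells (Homo sapiens) for inhibition, read by MTT assay, with a stated time of 72 h (a higher number here means a weaker inhibitor, a lower number a stronger inhibitor), are these:
Compound 1 `COc1cc(NC(C)CCCNC(=O)Nc2ccc(C(F)(F)F)cc2)c2ncccc2c1` gives 24000 nM 
Compound 2 `COc1cc(NC(C)CCCNC(=O)NNC(=O)Nc2cccc(C(F)(F)F)c2)c2ncccc2c1` gives 20000 nM 

Compound 2 at 20000 nM sits within the usual scatter of compound 1, so neither stands apart. Compound 3 `COc1cc(NC(C)CCCNC(=O)NNC(=O)Nc2ccc(O)cc2)c2ncccc2c1` has 4-hydroxyphenyl in place of 3-(trifluoromethyl)phenyl on an amide-type nitrogen, a change counted as 4-hydroxyphenyl in place of 3-(trifluoromethyl)phenyl on an amide-type nitrogen and not yet tested. Among the compounds with values here, no measured step shows what such a swap does in this assay here, so the estimated no change at the digits printed from compound 2 to compound 3 (within the scatter) is expected to stay within the scatter, with no direction favoured. For compound 3 the expected value is 20000 nM with a wide estimated range of 7000 nM to 60000 nM around it.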

Compound 3, half-maximal inhibitory concentration: > 100000 nM
Compound 3: no number, only a limit (the forecaster's own chance of this, stated with the estimate: 15%); middle value at least 5.0-fold (0.69 log units) away from the limit.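

In this assay, within the data shown here, the group on this amide-type nitrogen now matters for the first time: 4-hydroxyphenyl in place of 3-(trifluoromethyl)phenyl gives an at least 5.0-fold higher number from compound 2 to compound 3 (0.69 log units; beyond the scatter). The wider change of ((4-hydroxyphenyl)carbamoyl)amino in place of 4-(trifluoromethyl)phenyl gives an at least 4.1-fold higher number from compound 1 to compound 3 (0.61 log units; beyond the scatter). Compound 3 has only a limit of the assay, not a number, so both steps are minimum sizes: the limit of > 100000 nM in this assay, at which 1 of the 3 values shown sits.

The compounds shown do not separate the effect of the hydroxy group from that of its place on the ring. They also do not show how a plain phenyl or a 4-methoxyphenyl on that nitrogen would read.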